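The source may report more compounds than this note shows. Statements on the series, on what has been measured and on what is new or still open speak of the compounds shown alone.

Measured so far in a functional assay on EL4 cells (Mus musculus) for inhibition, tested at 100 uM; a higher number here means more inhibition at the concentration tested (going by the name of the read-out), a lower number less inhibition:
compound 1 `Nc1nccc2c1ncn2[C@H]1C[C@H](O)[C@@H](CO)O1` gives 89%
compound 2 `OC[C@H]1O[C@@H](n2cnc3c(Cl)nccc32)C[C@@H]1O` gives < 5%
compound 3 `OC[C@H]1O[C@@H](n2cnc3c(SCc4ccccc4)nccc32)C[C@@H]1O` gives 11%

The value of compound 2 is a limit of the assay, not a number (the limit of < 5% in this assay, at which 1 of the 3 values shown sits).

Compound 3 stands lowest of the two numbers; its nearest neighbour is compound 1, and the step of a number 78 percentage points lower from compound 1 to compound 3 (beyond the scatter) removes nearly all inhibition. Compound 4 `OC[C@H]1O[C@@H](n2cnc3cnccc32)C[C@@H]1O` strips the position bare: hydrogen in place of benzylsulfanyl on an aromatic carbon. Among the measured compounds shown here, the steps that bear on this change are a number 78 percentage points lower from compound 1 to compound 3 (beyond the scatter) and a number at least 6 percentage points higher from compound 2 to compound 3 (that floor lies within the scatter); the two groups other than amino both leave little inhibition, and the bare position is expected to behave alike. No step beyond the scatter is expected, a number 1 percentage points lower from compound 3 to compound 4 (within the scatter). For compound 4 the estimate in this assay is 10%, between 0% and 30%.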

Compound 4, a percentage reported as inhibition, at one concentration (the size of the read-out at that concentration, not a potency): < 5%
Compound 4: no number, only a limit; the forecaster's own chance of this, stated with the estimate: 35%; middle value at least 5 percentage points from the limit.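

In this assay compound 4 gives < 5%, a limit of the assay and not a number: the limit of < 5% in this assay, at which 2 of the 4 values shown sit.

Removing the group altogether gives a number at least 84 percentage points lower from compound 1 to compound 4 (beyond the scatter), so among the groups shown at this carbon only amino goes with high inhibition, and hydrogen does not restore it. Replacing benzylsulfanyl gives a number at least 6 percentage points lower from compound 3 to compound 4 (that floor lies within the scatter), which separates these two compounds by no more than the scatter, and the step between compound 2 and compound 4 cannot be read.

On these data alone, whether a methylamino or dimethylamino group at this carbon keeps the inhibition of compound 1 stays open. So does whether a hydroxyl group can stand in for amino.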